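Thiosemicarbazone series: aryl for benzyl on the thiourea nitrogen

The source may hold more compounds than are shown below. What is called first, only, known or untested is meant among the compounds shown, and "the series" means these compounds.

For the measured compounds named here, compound 1 `S=C(NCc1ccccc1)N/N=C/c1ccc2ccccc2n1` is the one member of the series with a numerical result: in a functional assay on SGC-7901 cells (Homo sapiens) for antiproliferative activity, read by sulforhodamine B assay, with a stated time of 72 h (a lower number here means a stronger inhibitor, a higher number a weaker inhibitor), compound 1 gives 53700 nM. Compound 2 `NC(=S)N/N=C/c1ccc2cccnc2n1` reaches only the assay limit, > 100000 nM in this assay. Compound 3 `NC(=S)N/N=C/c1cc2ccccc2s1` likewise sits at the limit, > 100000 nM in this assay. Going by the values given here, both therefore share (the limit of > 100000 nM in this assay, at which 2 of the 3 values shown sit), so no step between measured compounds can be sized, and compound 1 stands as the only placed point.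

The next compound, compound 4 `S=C(N/N=C/c1ccc2ccccc2n1)Nc1cccc(Cl)c1`, differs from compound 1 in one place: 3-chlorophenyl in place of benzyl on an amide-type nitrogen. Among the compounds with values here, with no measured step to lean on, the expectation rests on compound 1 alone, and the replacement of one aromatic group by another of the same heavy-atom count is expected to move this assay by little, if at all, beyond the scatter. Compound 4 is estimated to give 30000 nM in this assay, within 8000 nM to 100000 nM. The expected step of a 1.8-fold lower number from compound 1 to compound 4 (0.25 log units; within the scatter) is thus taken as small, leaning toward modestly stronger inhibition.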

Compound 4, half-maximal inhibitory concentration: 61300 nM
Compound 4: middle estimate off by 2.0-fold (0.31 log units), on the low side, within the range that was stated.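

For the compounds shown here, the change to 3-chlorophenyl gives a 1.1-fold higher number from compound 1 to compound 4 (0.06 log units; within the scatter) in this assay, the first sized step. On this amide-type nitrogen, whose other neighbour is the thiocarbonyl carbon, the read-out does not separate benzyl from 3-chlorophenyl, two groups with 7 heavy atoms and one six-membered aromatic ring of carbon only. This rests on one pair of compounds, and the data give no cause for it.

On these data alone, whether a morpholine, a carboxylic acid or a longer chain such as phenethyl on that nitrogen would move the number beyond the scatter remains open. The values of compound 2 and compound 3 are limits and not numbers, so no step to either can be read: the limit of > 100000 nM in this assay, at which 2 of the 4 values shown sit.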